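The source may report more compounds than this note shows. Statements on the series, on what has been measured and on what is new or still open speak of the compounds shown alone.

Series notes. Compound 1 `COc1ccccc1Nc1nc(SCc2cn(Cc3ccccc3Cl)nn2)nc(-c2ccccc2)c1C#N` gives 9670 nM in a functional assay on ECa-109 cells (Homo sapiens) for inhibition, read by MTT assay, with a stated time of 72 h; a lower number here means a stronger inhibitor, a higher number a weaker inhibitor. Compound 2 `N#Cc1c(Nc2ccc(F)cc2)nc(SCc2cn(Cc3ccccc3Cl)nn2)nc1-c1ccccc1` gives 25800 nM in this assay and so stands as the higher of the two numbers on hand. The step of a 2.7-fold higher number from compound 1 to compound 2 (0.43 log units; beyond the scatter) is the only measured one, and it exchanges the whole aryl group on the nitrogen rather than a single substituent. Compound 3 `Cc1ccc(Nc2nc(SCc3cn(Cc4ccccc4Cl)nn3)nc(-c3ccccc3)c2C#N)cc1` differs from compound 2 by methyl in place of fluoro on an aromatic carbon. Among the compounds with values here, no measured step swaps one small group for another on that aromatic carbon, so the expected change a 1.3-fold lower number from compound 2 to compound 3 (0.11 log units; within the scatter) is none beyond the scatter. For compound 3 the estimate in this assay is 20000 nM, within 8000 nM to 50000 nM.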

Compound 3, half-maximal inhibitory concentration: > 64000 nM
Compound 3 gave a limit, no number; the forecaster's own chance of this, stated with the estimate: 10%; middle value at least 3.2-fold (0.50 log units) from the limit.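

Methyl in place of fluoro on the aromatic carbon para to a large group is not a neutral exchange in this assay: the step is an at least 2.4-fold higher number from compound 2 to compound 3 (0.39 log units; beyond the scatter), the first measured change of a single substituent at this place. The wider exchange of 4-methylphenyl for 2-methoxyphenyl gives an at least 6.6-fold higher number from compound 1 to compound 3 (0.82 log units; beyond the scatter), which leaves compound 1 with the lowest number of the three. Compound 3 gives a limit and not a number, so both steps are open-ended: the limit of > 64000 nM in this assay, at which 1 of the 3 values shown sits.

On these data alone, how far compound 3 lies past that limit stays open. Also open, as far as these compounds go, is how a chlorine, an amine or a carboxylic acid on the same carbon would read.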